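Ethyl and Fluorine Enter Where Methyls Leave

The source may hold more compounds than are shown below. What is called first, only, known or untested is meant among the compounds shown, and "the series" means these compounds.

In an assay on isolated protein for inhibition of Dihydrofolate reductase (Homo sapiens), read by spectrophotometry (on this read-out lower numbers stand for stronger inhibition and higher numbers for weaker inhibition), compound 1 `COc1ccc(N(C)Cc2nc3cc(C(F)(F)F)ccc3nc2-c2ccccc2)cc1` gives 3000 nM.
In this assay compound 2 `Cc1ccc(N(C)Cc2nc3cc(C(F)(F)F)ccc3nc2-c2ccccc2)cc1` gives 11000 nM.

Compound 2 stands at the highest of the two numbers; the step of a 3.7-fold higher number from compound 1 to compound 2 (0.56 log units; beyond the scatter) separates it from compound 1 and lies beyond the scatter. Compound 3 `CCN(Cc1nc2cc(C(F)(F)F)ccc2nc1-c1ccccc1)c1ccc(F)cc1` differs from compound 2 by ethyl(4-fluorophenyl)amino in place of methyl(4-methylphenyl)amino on a saturated chain carbon bound to an aromatic carbon. Within the data shown here, no measured step swaps a methyl for fluorine on the ring or lengthens the chain on the nitrogen; the one measured step, a 3.7-fold higher number from compound 1 to compound 2 (0.56 log units; beyond the scatter), concerns a different pair of groups at the same aromatic carbon and shows that this part of the molecule can move the number by a modest amount. A change of comparable size is therefore expected in this assay, without a firm direction, and a number near that of compound 2 or somewhat lower. Compound 3 is estimated at 8000 nM, with a range from 2500 nM to 25000 nM. For compound 3 this expectation means a step of a 1.4-fold lower number from compound 2 to compound 3 (0.14 log units; within the scatter).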

Compound 3, inhibition constant: 3000 nM
Compound 3: middle estimate off by 2.7-fold (0.43 log units), on the high side; measured number inside the range.
By their numbers in this assay, from the lowest: compounds 1 and 3 (each within the scatter of the next); then compound 2.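

In this assay, ethyl(4-fluorophenyl)amino in place of methyl(4-methylphenyl)amino gives a 3.7-fold lower number from compound 2 to compound 3 (0.56 log units; beyond the scatter), which shows that a change on this saturated chain carbon can undo the loss seen with the methyl compound. Measured against the methoxy compound, the same group gives no change at the digits printed from compound 1 to compound 3 (within the scatter), so ethyl(4-fluorophenyl)amino and (4-methoxyphenyl)(methyl)amino stand level at this position. Nothing shown here explains either step.

Ethyl and fluorine enter together, so the compounds shown cannot assign the lower number to one or the other. As far as these compounds go, it also remains open whether chlorine in place of the fluorine, or a propyl chain in place of the ethyl, would shift the number further.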